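The compounds below may be only part of what the source reports. "The series", "measured", "known", "first", "only" and "open" are said of these compounds alone.

Working notes on the series. The shared core is that of compound 1 `CC(C)n1c(/C=C2/C(=O)Nc3ccccc32)nc2ccccc21`, which in a functional assay on A549 cells (Homo sapiens) for cytotoxicity, read by MTT assay, with a stated time of 48 h (a higher number here means a weaker inhibitor, a lower number a stronger inhibitor), gives 35300 nM. Compound 2 `Cn1c(/C=C2/C(=O)Nc3ccc([N+](=O)[O-])cc32)nc2ccccc21` carries a nitro group on the carbon ring and a methyl on the aromatic nitrogen. In this assay compound 2 returns only a limit, > 50000 nM. Compound 3 `CCn1c(/C=C2/C(=O)Nc3ccc([N+](=O)[O-])cc32)nc2ccccc21` differs from compound 2 by methyl in place of hydrogen on a saturated chain carbon bound to an aromatic nitrogen. In this assay compound 3 also returns a limit, > 50000 nM. For the measured compounds named here, the one measured step is a step that the two limits leave unreadable from compound 2 to compound 3; both ends sit at the limit of > 50000 nM in this assay, at which 2 of the 3 values shown sit, so its size cannot be read. Compound 2 therefore stands at the limit, with one of the other values also a limit and only compound 1 given as a number.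

Compound 4 `Cn1c(/C=C2/C(=O)Nc3ccc(Cl)cc32)nc2ccccc21` is not yet measured. Its difference from compound 2 is chloro in place of nitro on an aromatic carbon. Going by the values given here, no measured step touches this exchange, and the single step available, being unreadable, gives no size to carry over. No change beyond the scatter is assumed. The estimate for compound 4 is 45000 nM, with a range from 15000 nM to 150000 nM. The expected step is an at least 1.1-fold lower number from compound 2 to compound 4 (0.04 log units; that floor lies within the scatter), with a fair chance that only a limit is reported again.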

Compound 4, half-maximal inhibitory concentration: 39700 nM
Compound 4: the middle estimate sits 1.1-fold (0.05 log units) above what was measured; low and high end bracket the measured number.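

For the compounds shown here, on the aromatic carbon meta to a fused ring and para to a fused ring, the exchange of nitro for chloro in this assay gives the first step with any readable size: an at least 1.2-fold lower number from compound 2 to compound 4 (0.10 log units; that floor lies within the scatter). With the methyl on the aromatic nitrogen kept in place, compound 4 returns a number, 39700 nM, so this position now has one measured value to which later exchanges can be compared. The step remains only a floor, and the true distance for this change cannot be given, because compound 2 stands at a limit: the limit of > 50000 nM in this assay, at which 2 of the 4 values shown sit.

Whether an amine or a methoxy group on this aromatic carbon would give a step beyond the scatter remains open, and a comparison of chloro with plain hydrogen under the same methyl is also missing from the compounds shown. Also open, as far as these compounds go, is whether chloro at this position gives a similar number with a longer chain, such as ethyl or isopropyl, on the aromatic nitrogen.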